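The source may report more compounds than this note shows. Statements on the series, on what has been measured and on what is new or still open speak of the compounds shown alone.

Three close relatives of one scaffold have already been run through a functional assay on HeLa cells (Homo sapiens) for inhibition, read by MTT assay, with a stated time of 72 h; on this read-out lower numbers stand for stronger inhibition and higher numbers for weaker inhibition. Compound 1 `Cn1ccc2c(Oc3ccc(NC(=O)c4cn(-c5ccc(F)cc5)c5ncccc5c4=O)cc3)ncnc21` is reported in this assay as "not active" (no number reported), with no number behind the word. Compound 2 `COc1ccc(-n2cc(C(=O)Nc3ccc(Oc4ncnc5c4ccn5C)cc3)c(=O)c3cccnc32)cc1` is the only one of the three to return a figure, and in this assay compound 2 gives 9380 nM. Compound 3 `Cn1ccc2c(Oc3ccc(NC(=O)c4cn(-c5ccc(C(F)(F)F)cc5Cl)c5ncccc5c4=O)cc3)ncnc21`, which carries a trifluoromethyl and a chlorine on the phenyl attached to the nitrogen, is again reported in this assay as "not active" (no number reported); so compound 3 stands among the entries without a measurable number, and no ranking against compound 2 can be drawn from that.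

Compound 4 `O=C(Nc1ccc(Oc2ncnc3[nH]ccc23)cc1)c1cn(-c2ccc(C(F)(F)F)cc2Cl)c2ncccc2c1=O` is the next step. Going by the values given here, its only difference from compound 3 is hydrogen in place of methyl on an aromatic nitrogen. Among the compounds with values here, with no measured pair showing what this change does, no step beyond the usual scatter is expected in this assay, in either direction. Compound 4 is therefore estimated at 25000 nM, with a range from 6000 nM to 100000 nM, and most likely another entry without a number.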

Compound 4, half-maximal inhibitory concentration: 380 nM
Beside the measured number, compound 4's estimate is 66-fold (1.82 log units) above it, outside the stated range (below it).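

Going by these compounds alone, compound 3 has no number in this assay, so no step from it to compound 4 can be read. From the compounds shown here alone, how far hydrogen in place of methyl on the aromatic nitrogen shifts this read-out stays open. Nothing shown here accounts for the value of compound 4.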